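The source may report more compounds than this note shows. Statements on the series, on what has been measured and on what is new or still open speak of the compounds shown alone.

Among the compounds with values here, in a functional assay on CHO cells for antagonist activity at sphingosine 1-phosphate receptor 2 (Homo sapiens), read by fluorescence and calcium flux, with a stated time of 3 min (on this read-out higher numbers stand for weaker inhibition and lower numbers for stronger inhibition), compound 3 `Cc1cc(NNC(=O)Nc2cc(Cl)nc(Cl)c2)ncc1-c1cnn(C)c1` gives 2600 nM, the only finite number among the three measured compounds. Compound 1 `Cc1cc(C#N)nc(NNC(=O)Nc2cc(Cl)nc(Cl)c2)c1` gives > 6600 nM, which is a limit of the assay rather than a number. Compound 2 `Cc1cc(CO)nc(NNC(=O)Nc2cc(Cl)nc(Cl)c2)c1` likewise gives > 6600 nM, again a limit. Compound 2 differs from compound 1 by a hydroxymethyl in place of cyano on an aromatic carbon, and the step that the two limits leave unreadable from compound 1 to compound 2 cannot be read because both values sit at the limit of > 6600 nM in this assay, at which 2 of the 3 values shown sit. Compound 3 therefore stands alone with a readable number, and neither of the other two measured compounds helps to judge a change made to it.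

Compound 4 `Cc1cc(NNC(=O)Nc2cc(Cl)nc(Cl)c2)ncc1-c1cn(C)nc1C` differs from compound 3 only in methyl in place of hydrogen on an aromatic carbon: a methyl in place of hydrogen on an aromatic carbon, so that the 1-methyl-1H-pyrazol-4-yl of compound 3 becomes 1,3-dimethyl-1H-pyrazol-4-yl. No measured step touches this part of the structure; the one step shown concerns a different group and is unreadable in any case. Without a precedent, the expected step of no change at the digits printed from compound 3 to compound 4 (within the scatter) is none beyond the usual scatter of repeated measurements. Compound 4 is therefore estimated at 2600 nM in this assay, with a range from 1000 nM to 6600 nM.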

Compound 4, half-maximal inhibitory concentration: > 1400 nM
Compound 4 was reported as a limit; the forecaster's own chance of this, stated with the estimate: 20%; the middle value is on the limit's open side.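

In this assay compound 4 gives > 1400 nM, which is a limit of the assay and not a number. Within the data shown here, no step from compound 3 to compound 4 can be read from this result: the limit of > 1400 nM in this assay, at which 1 of the 4 values shown sits. The compounds shown leave open whether 1,3-dimethyl-1H-pyrazol-4-yl in place of 1-methyl-1H-pyrazol-4-yl strengthens, weakens or leaves unchanged the inhibition.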